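The compounds below may be only part of what the source reports. "The series", "measured", "known", "first", "only" and "open" are said of these compounds alone.

Compound 1 `O=S(=O)(NCCCNCc1ccc(Cl)cc1)c1cc(C(F)(F)F)cc(C(F)(F)F)c1` is the reference point for this step. In a functional assay on HPAC cells (Homo sapiens) for inhibition, read by MTT assay, with a stated time of 72 h (a higher number here means a weaker inhibitor of growth, a lower number a stronger inhibitor of growth), compound 1 gives 2800 nM. Among the measured compounds shown here, compound 2 `O=S(=O)(NCCNCc1ccc(-c2ccccc2)cc1)c1cc(C(F)(F)F)cc(C(F)(F)F)c1` is the only other measured member of the series; in this assay compound 2 gives 2800 nM. Compound 1 therefore stands level with compound 2 at the digits shown, the two values lying within the scatter of each other, so no order between them can be read and neither can be called the stronger inhibitor of growth.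

Compound 3 `O=S(=O)(NCCCNCc1ccc(Cl)c(C(F)(F)F)c1)c1cc(C(F)(F)F)cc(C(F)(F)F)c1` has not yet been measured in this assay. It differs from compound 1 in a single place: trifluoromethyl in place of hydrogen on an aromatic carbon. For the measured compounds named here, no step between measured compounds bears on this change, so the series itself gives no indication of how a trifluoromethyl entering the 4-chlorophenyl end alters growth inhibition. The working expectation is a step of a 1.4-fold lower number from compound 1 to compound 3 (0.15 log units; within the scatter), small, leaning toward a lower number, and not clearly beyond the scatter. For compound 3 the value in this assay is expected at 2000 nM, with a range from 800 nM to 5000 nM.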

Compound 3, concentration for 50% growth inhibition: 3000 nM
Compound 3: the middle estimate sits 1.5-fold (0.18 log units) below what was measured; low and high end bracket the measured number.
By their numbers in this assay, from the lowest: compounds 1, 2 and 3 (each within the scatter of the next).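

In this assay, among the compounds shown here, the change from 4-chlorophenyl to 4-chloro-3-(trifluoromethyl)phenyl gives a 1.1-fold higher number from compound 1 to compound 3 (0.03 log units; within the scatter), the first step between two measured compounds that differ in one place. This aromatic carbon, ortho to a chloro group, therefore takes a trifluoromethyl of 4 heavy atoms in place of hydrogen with the two values remaining within the scatter, so no gain or loss in growth inhibition can be read from this change. Nothing measured here offers an explanation for this outcome, and this single step cannot show whether the position is generally tolerant.

Still open, as far as these compounds go, is whether a smaller or differently built group on the same carbon, such as a nitrile, a methoxy group, an amine or a carboxylic acid, would also stay within the scatter of compound 1. From the compounds shown here alone, it is also open whether trifluoromethyl at this position would give the same small step on a compound with a longer chain, or with the chloro group replaced by another substituent.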